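The source may hold more compounds than are shown below. What is called first, only, known or untested is meant among the compounds shown, and "the series" means these compounds.

Of the compounds shown here, two built on a shared core have been measured in a functional assay on SK-MEL-5 cells (Homo sapiens) for inhibition, read by sulforhodamine B assay, with a stated time of 48 h; a lower number here means that less compound is tolerated, a higher number that more compound is tolerated. Compound 1 `O=C(Nc1cccc(-n2cc(-c3ccncc3)c(-c3ccc(Cl)c(O)c3)n2)c1)Nc1ccc(Cl)c(Cl)c1` gives 2350 nM in this assay. Compound 2 `COc1cc(-c2nn(-c3cccc(NC(=O)c4ccc(Cl)c(C(F)(F)F)c4)c3)cc2-c2ccncc2)ccc1Cl` differs from compound 1 in its linker and in the substitution of its aryl groups. In this assay compound 2 gives 31800 nM. Of the two numbers, compound 2 holds the higher one, and the gap to compound 1 lies well beyond the usual scatter, so compound 2 is the one of which the cells tolerate more.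

Compound 3 `COc1cc(-c2nn(-c3cccc(NC(=O)c4cccc(C(F)(F)F)c4)c3)cc2-c2ccncc2)ccc1Cl` has not yet been measured in this assay. It differs from compound 2 in one place: hydrogen in place of chloro on an aromatic carbon. Going by the values given here, no pair of measured compounds isolates this change, so there is no precedent within the two numbers for its size. The estimate therefore rests on the value of compound 2 alone and on the modesty of the change from 4-chloro-3-(trifluoromethyl)phenyl to 3-(trifluoromethyl)phenyl. For compound 3 the expected step of a 1.3-fold higher number from compound 2 to compound 3 (0.10 log units; within the scatter) is small, not clearly beyond the scatter, with a slight lean toward a higher number. Compound 3 is estimated at 40000 nM in this assay, with a range from 12000 nM to 130000 nM.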

Compound 3, concentration lethal to 50% of the cells: 40600 nM
Compound 3: the middle estimate sits 1.0-fold (0.01 log units) below what was measured, within the range that was stated.
By their numbers in this assay, from the lowest: compound 1; then compounds 2 and 3 (each within the scatter of the next).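

In this assay the chloro on this aromatic carbon, ortho to a trifluoromethyl group and para to a large group, proves dispensable for the reading: with hydrogen in its place, the step of a 1.3-fold higher number from compound 2 to compound 3 (0.11 log units; within the scatter) stays within the scatter, so compound 2 and compound 3 cannot be told apart. Going by these compounds alone, this is the first pair that isolates a single change, and it shows that removing one chlorine atom from the 4-chloro-3-(trifluoromethyl)phenyl group, leaving 3-(trifluoromethyl)phenyl, does not by itself move the number beyond what repeated measurements would give. No supporting data are available that could explain this outcome or tie it to any property of the group.

Within the data shown here, the single pair leaves open whether this aromatic carbon is equally undemanding of other substituents, such as a fluoro, a nitrile, an amine or a carboxylic acid, since chloro and hydrogen are the only two seen there. Among these compounds, it also leaves open what would follow if the neighbouring trifluoromethyl group itself gave way to hydrogen or to a methyl group, as no pair isolates a change at that group.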